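From cyclopropyl to phenyl on a sulfonyl sulfur

The source may report more compounds than this note shows. Statements on the series, on what has been measured and on what is new or still open speak of the compounds shown alone.

- Compound 1 `COc1ccc(-c2c(C)nc3c(N4CC[C@@H](NC(=O)c5ccccc5)C4)cc(C)nn23)cc1OC`: > 95%
- Compound 2 `COc1ccc(-c2c(C)nc3c(N4CC[C@@H](NS(=O)(=O)C5CC5)C4)cc(C)nn23)cc1OC`: > 95%

Both compounds were tested in an ADME assay on microsomes from liver (Mus musculus) for metabolic stability, read by LC-MS, with NADPH named in the record, with a stated time of 60 min, tested at 1 uM, in the absence of a further agent; a higher number here means that more of the compound is left, a lower number that less of the compound is left. For compound 2, the reading of > 95% is a limit of the assay, not a number. Compound 1 also gives a limit, > 95%. So far, the data show (the limit of > 95% in this assay, at which 2 of the 2 values shown sit).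

Compound 3 `COc1ccc(-c2c(C)nc3c(N4CC[C@@H](NS(=O)(=O)c5ccccc5)C4)cc(C)nn23)cc1OC` changes one group of compound 2: phenyl in place of cyclopropyl on a sulfonyl sulfur. Going by the values given here, only one measured step bears on this, a step that the two limits leave unreadable from compound 1 to compound 2. It replaces a different group, and it gives no size to carry over. With so little to go on, no change beyond the usual scatter is expected in this assay. The expected step is a number at least 3 percentage points lower from compound 2 to compound 3 (that floor lies within the scatter). For compound 3, the estimate is 92%, with an expected range of 75% to 100%.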

Compound 3, percent of the compound remaining: > 95%
Compound 3 gave a limit, no number (the forecaster's own chance of this, stated with the estimate: 55%); middle value at least 3 percentage points from the limit.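

Going by these compounds alone, compound 1, compound 2 and compound 3 all give limits of the assay rather than numbers, so no step among them can be read: the limit of > 95% in this assay, at which 3 of the 3 values shown sit. Going by these compounds, whether phenyl, cyclopropylsulfonyl's cyclopropyl or benzoyl makes any difference in this assay stays open.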